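The compounds below may be only part of what the source reports. "The series", "measured", "known", "first", "only" and "open" are said of these compounds alone.

Measured compounds:
- compound 1 `O=C(Nc1cccc(-n2cc(-c3ccncc3)c(-c3cc(O)cc(Cl)c3)n2)c1)Nc1ccc(Cl)c(C(F)(F)F)c1` — -40%
- compound 2 `COc1cc(Cl)cc(-c2nn(-c3cccc(NC(=O)Nc4ccc(Cl)c(C(F)(F)F)c4)c3)cc2-c2ccncc2)c1` — -30%

In a functional assay on SR cells (Homo sapiens) for inhibition, read by sulforhodamine B assay, with a stated time of 48 h, tested at 100 uM (on this read-out higher numbers stand for a weaker effect at the one concentration tested and lower numbers for a stronger effect), compound 1 gives -40%. Compound 2 gives -30% in this assay; the step of a number 10 percentage points higher from compound 1 to compound 2 (within the scatter) is within the scatter, so the two numbers show no separation and compound 2 cannot be placed above or below compound 1.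

Compound 3 `COc1cc(Cl)cc(-c2nn(-c3cccc(NC(=O)c4cccc(C(F)(F)F)c4)c3)cc2-c2ccncc2)c1` has not yet been measured in this assay. It differs from compound 2 by 3-(trifluoromethyl)phenyl in place of (4-chloro-3-(trifluoromethyl)phenyl)amino on a carbonyl carbon. No measured step bears on this part of the molecule: the only step shown, a number 10 percentage points higher from compound 1 to compound 2 (within the scatter), concerns the methyl on an oxygen and is within the scatter, so it gives no guide. The expectation rests on the change alone and is uncertain. A step toward a weaker effect is expected, a number 40 percentage points higher from compound 2 to compound 3 (beyond the scatter), with a wide range. Compound 3 is estimated at 10% in this assay, between -40% and 60%.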

Compound 3, a percentage reported as activity, at one concentration (the size of the read-out at that concentration, not a potency): 15%
Compound 3: middle estimate off by 5 percentage points, on the low side, and the stated range covers the measured number.
By their numbers in this assay, from the lowest: compounds 1 and 2 (each within the scatter of the next); then compound 3.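

Within the data shown here, on the carbonyl carbon whose other neighbour is the amide-type nitrogen, 3-(trifluoromethyl)phenyl in place of (4-chloro-3-(trifluoromethyl)phenyl)amino gives the first step beyond the scatter in this assay with a number 45 percentage points higher from compound 2 to compound 3 (beyond the scatter) toward a weaker effect at the one concentration tested. This position therefore responds to change, whereas the methyl on the oxygen left compound 1 and compound 2 without separation. No measurement at hand accounts for this step.

The change removes the amino nitrogen and the chlorine together, and the compounds shown do not separate the part each plays in the step. Also open, as far as these compounds go, is how this position reads with a morpholine or a carboxylic acid on the carbonyl carbon.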